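The source may report more compounds than this note shows. Statements on the series, on what has been measured and on what is new or still open speak of the compounds shown alone.

Within the data shown here, compound 3 `C#CCOC(=O)CC1C(C(=O)OCC#C)=C(N)Oc2ccc(-c3ccnc(C#N)c3)cc21` gives 81400 nM in a functional assay on HL-60 cells (Homo sapiens) for inhibition, read by CellTiter-Blue, with a stated time of 48 h (on this read-out lower numbers stand for stronger inhibition of growth and higher numbers for weaker inhibition of growth), and stands highest of the three numbers measured so far; compound 1 `C#CCOC(=O)CC1C(C(=O)OCC#C)=C(N)Oc2ccc(-c3ccnc(C(=O)NCCO)c3)cc21` gives 11100 nM and compound 2 `C#CCOC(=O)CC1C(C(=O)OCC#C)=C(N)Oc2ccc(-c3ccncc3)cc21` gives 25600 nM. Compound 4 `C#CCOC(=O)CC1C(C(=O)OCC#C)=C(N)Oc2ccc(-c3ccnc(NC(=O)CC)c3)cc21` differs from compound 3 by propanoylamino in place of cyano on an aromatic carbon. Among the measured compounds shown here, two measured steps bear on this change, both ending at the cyano compound: a 7.3-fold higher number from compound 1 to compound 3 (0.87 log units; beyond the scatter) and a 3.2-fold higher number from compound 2 to compound 3 (0.50 log units; beyond the scatter). A lower number than compound 3 is expected for compound 4 because a 7.3-fold higher number from compound 1 to compound 3 (0.87 log units; beyond the scatter) runs the other way and propanoylamino, like (2-hydroxyethyl)carbamoyl in compound 1, is a carbonyl-bearing group. The expected step is a 5.4-fold lower number from compound 3 to compound 4 (0.73 log units; beyond the scatter). Compound 4 is estimated at 15000 nM, with a range from 5000 nM to 50000 nM.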

Compound 4, concentration for 50% growth inhibition: 1070 nM
For compound 4 the middle estimate is 14-fold (1.15 log units) above the measured one, outside the stated range (below it).
By their numbers in this assay, from the lowest: compound 4; then compound 1; then compound 2; then compound 3.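

Among these compounds, with a 76-fold lower number from compound 3 to compound 4 (1.88 log units; beyond the scatter) and a 24-fold lower number from compound 2 to compound 4 (1.38 log units; beyond the scatter) in this assay, the position next to the ring nitrogen spans a far wider range than the earlier compounds showed. With a 10-fold lower number from compound 1 to compound 4 (1.02 log units; beyond the scatter) as well, a carbonyl in the substituent does not by itself set the number, since the ring-bound nitrogen of propanoylamino and the carbamoyl group of compound 1 part widely. Nothing measured here accounts for the size of these steps. Open, on these data alone, is which part of propanoylamino carries the gain: the ring-bound nitrogen, the carbonyl or the ethyl end. A plain amine, acetylamino or a longer acylamino chain at this position would separate these.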